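A few compounds are considered here, and "the series" means these few. Any claim that something is new, unique, unknown or untested is made for them only; others in the source may bear on it.

Working notes on the series. In a functional assay on MCF7 cells (Homo sapiens) for inhibition, with a stated time of 96 h (a higher number here means a weaker inhibitor, a lower number a stronger inhibitor), compound 1 `COc1cc(C(=O)c2cn(-c3ccc(C)cc3)cc2-c2ccccn2)cc(OC)c1OC` gives 36 nM, compound 2 `COc1cc(C(=O)c2cn(-c3ccc(C)cc3)cc2-c2cccnc2)cc(OC)c1OC` gives 19 nM and compound 3 `COc1cc(C(=O)c2cn(-c3ccc(F)cc3)cc2-c2ccccn2)cc(OC)c1OC` gives 73 nM. Compound 2 differs from compound 1 by pyridin-3-yl in place of pyridin-2-yl on an aromatic carbon, a change that brought a 1.9-fold lower number from compound 1 to compound 2 (0.28 log units; within the scatter). The core of compound 3 differs from that of compound 1 by fluoro in place of methyl on an aromatic carbon, which brought a 2.0-fold higher number from compound 1 to compound 3 (0.31 log units; beyond the scatter). Compound 4 `COc1cc(C(=O)c2cn(-c3ccc(F)cc3)cc2-c2cccnc2)cc(OC)c1OC` has not yet been measured in this assay; it differs from compound 3 by pyridin-3-yl in place of pyridin-2-yl on an aromatic carbon. This is the same kind of change as that between compound 1 and compound 2, though around the place the ring atom two ring bonds from the changed carbon bears a 4-fluorophenyl group rather than a 4-methylphenyl group. Within the data shown here, a step of a 1.8-fold lower number from compound 3 to compound 4 (0.26 log units; within the scatter) is expected, as the single earlier step of this kind, a 1.9-fold lower number from compound 1 to compound 2 (0.28 log units; within the scatter), is the only guide. Compound 4 is accordingly estimated at 40 nM, with a range from 20 nM to 90 nM.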

Compound 4, half-maximal inhibitory concentration: 39 nM
Beside the measured number, compound 4's estimate is 1.0-fold (0.01 log units) above it; the measured number falls inside the stated range.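

In this assay, pyridin-3-yl in place of pyridin-2-yl on the core bearing the 4-fluorophenyl group gave a 1.9-fold lower number from compound 3 to compound 4 (0.27 log units; within the scatter), and the step agrees with the one on the core bearing the 4-methylphenyl group: the same change on two cores in this assay, a 1.9-fold lower number (0.28 log units; within the scatter) from compound 1 to compound 2 and a 1.9-fold lower number (0.27 log units; within the scatter) from compound 3 to compound 4, 1.0-fold (0.01 log units) apart, within the scatter of two such steps

Fluoro in place of methyl gave a 2.1-fold higher number from compound 2 to compound 4 (0.31 log units; beyond the scatter), and this step also carries over between the two cores: the same change on two cores in this assay, a 2.0-fold higher number (0.31 log units; beyond the scatter) from compound 1 to compound 3 and a 2.1-fold higher number (0.31 log units; beyond the scatter) from compound 2 to compound 4, 1.0-fold (0.01 log units) apart, within the scatter of two such steps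

Across these four compounds the two changes thus behave independently, but this rests on only two cores per change, and each pyridine step on its own lies within the scatter, so only the agreement between steps is shown, not a firm effect of that change.

Open, on these data alone, is whether the agreement extends to a pyridin-4-yl group in place of pyridin-3-yl, or to a 4-aminophenyl or 4-methoxyphenyl group in place of the 4-fluorophenyl group. As far as these compounds go, whether it holds in any other cell line also stays open.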